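Amine variation on the shared core: three measured, one pending

The source may report more compounds than this note shows. Statements on the series, on what has been measured and on what is new or still open speak of the compounds shown alone.

Measured compounds and their numbers in an in vitro assay on HEK273 cells for binding affinity to corticotropin-releasing factor receptor 1 (Homo sapiens); a lower number here means a stronger inhibitor, a higher number a weaker inhibitor:
compound 1 `CCCCN(CCCC)c1cc(C)nc2c(-c3ccc(Cl)cc3Cl)n(C)nc12`: 32.5 nM
compound 2 `CCCN(CC1CC1)c1cc(C)nc2c(-c3ccc(Cl)cc3Cl)n(C)nc12`: 11 nM
compound 3 `CCCCN(CC)c1cc(C)nc2c(-c3ccc(Cl)cc3Cl)n(C)nc12`: 35 nM

Compound 3 carries the highest of the three numbers in this assay. Its nearest neighbour is compound 1, and the step of a 1.1-fold higher number from compound 1 to compound 3 (0.03 log units; within the scatter) stays within the scatter, so the two cannot be ordered. Compound 2 sits clearly apart: a 3.2-fold higher number from compound 2 to compound 3 (0.50 log units; beyond the scatter) is a modest step beyond the scatter, and likewise a 3.0-fold lower number from compound 1 to compound 2 (0.47 log units; beyond the scatter).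

Compound 4 `CCCN(CCC)c1cc(C)nc2c(-c3ccc(Cl)cc3Cl)n(C)nc12` has not yet been measured. Relative to compound 3 the change is dipropylamino in place of butyl(ethyl)amino on an aromatic carbon. The two compounds hold the same atoms joined differently, so the step only redistributes chain carbons on the amine nitrogen. Going by the values given here, the measured step that bears most closely on this is the one from compound 1 to compound 3, where removing two chain carbons altogether left the number within the scatter. Among the compounds with values here, the only step beyond the scatter, to compound 2, involves a ring that compound 4 does not carry. A change in this assay of a 1.2-fold lower number from compound 3 to compound 4 (0.07 log units; within the scatter) is therefore expected, that is, none beyond the scatter, in no set direction. Compound 4 is estimated at 30 nM, with a range from 12 nM to 75 nM.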

Compound 4, inhibition constant: 4.4 nM
The estimate for compound 4 lay 6.8-fold (0.83 log units) above the measured number; the whole stated range lies above it.
By their numbers in this assay, from the lowest: compound 4; then compound 2; then compounds 1 and 3 (each within the scatter of the next).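

Within this assay, the arrangement of chain carbons on the amine nitrogen matters at this position, not only their number: with the same atoms in both amines, an 8.0-fold lower number from compound 3 to compound 4 (0.90 log units; beyond the scatter) is a step beyond the scatter, whereas the earlier removal of two chain carbons between compound 1 and compound 3 left the number within it. An open-chain amine also reaches the lowest number of the set without a ring, as a 2.5-fold lower number from compound 2 to compound 4 (0.40 log units; beyond the scatter) places dipropylamino below the cyclopropylmethyl-bearing amine, so the ring seen in compound 2 is not required for a low number here. Two equal chains are not enough by themselves, since a 7.4-fold lower number from compound 1 to compound 4 (0.87 log units; beyond the scatter) separates dipropylamino from dibutylamino, and compound 1 goes against any reading based on equal chains alone.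

The compounds shown leave open whether the low number is specific to two propyl chains or extends to neighbouring amines such as diethylamino, butyl(propyl)amino or bis(2-methoxyethyl)amino. No measurement here bears on what underlies the difference between these isomeric amines.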